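Aryl thiosemicarbazones: fluorophenyl replaces bromophenyl on the thiourea nitrogen

The compounds below may be only part of what the source reports. "The series", "measured", "known", "first", "only" and "open" are said of these compounds alone.

The series shares one core, seen in compound 1 `Fc1cccc(NC(=S)N/N=C/c2ccc3ccccc3n2)c1`, which in a functional assay on HeLa cells (Homo sapiens) for antiproliferative activity, read by sulforhodamine B assay, with a stated time of 72 h (on this read-out lower numbers stand for stronger inhibition and higher numbers for weaker inhibition), gives 70100 nM. Compound 2 `COc1cccc(NC(=S)N/N=C/c2ccc3ccccc3n2)c1` carries methoxy in place of fluoro on an aromatic carbon; in this assay compound 2 gives 74500 nM, a step of a 1.1-fold higher number from compound 1 to compound 2 (0.03 log units; within the scatter). Compound 3 `S=C(N/N=C/c1ccc2ccccc2n1)Nc1ccccc1Br` bears 2-bromophenyl on the amide-type nitrogen. In this assay compound 3 returns only a limit, > 100000 nM, so its exact position is not known (the limit of > 100000 nM in this assay, at which 1 of the 3 values shown sits). Measured against the two numbers, the steps of an at least 1.4-fold higher number from compound 1 to compound 3 (0.15 log units; that floor lies within the scatter) and an at least 1.3-fold higher number from compound 2 to compound 3 (0.12 log units; that floor lies within the scatter) are floors only.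

Compound 4 `Fc1ccc(NC(=S)N/N=C/c2ccc3ccccc3n2)cc1` differs from compound 3 by 4-fluorophenyl in place of 2-bromophenyl on an amide-type nitrogen. The two measured steps that alter the aryl on the amide-type nitrogen, both ending at compound 3, gave floors that lie within the scatter, and compound 1, which carries 3-fluorophenyl on that nitrogen, sits at a number. A return to a number is therefore expected for compound 4, of a size that the floors cannot fix. Compound 4 is expected at 80000 nM, between 40000 nM and 160000 nM. That corresponds to an expected step of an at least 1.2-fold lower number from compound 3 to compound 4 (0.09 log units; that floor lies within the scatter), toward lower numbers, though with compound 3 known only as a limit the step may also fall within the scatter.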

Compound 4, half-maximal inhibitory concentration: 33200 nM
Compound 4: middle estimate off by 2.4-fold (0.38 log units), on the high side; the whole stated range lies above it.
By their numbers in this assay, from the lowest: compound 4; then compounds 1 and 2 (each within the scatter of the next). At a limit, above all of these: compound 3.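

The aryl on the amide-type nitrogen now gives steps beyond the scatter between exact numbers in this assay: 4-fluorophenyl in place of 3-fluorophenyl gives a 2.1-fold lower number from compound 1 to compound 4 (0.32 log units; beyond the scatter), and 4-fluorophenyl in place of 3-methoxyphenyl gives a 2.2-fold lower number from compound 2 to compound 4 (0.35 log units; beyond the scatter). Going by these compounds alone, the one earlier step between exact numbers, methoxy in place of fluoro, lay within the scatter, and both earlier floors at compound 3 did too, whereas 4-fluorophenyl in place of 2-bromophenyl gives an at least 3.0-fold lower number from compound 3 to compound 4 (0.47 log units; beyond the scatter), the first floor at compound 3 that clears the scatter. Compound 3 remains a limit, and this step is a floor only: the limit of > 100000 nM in this assay, at which 1 of the 4 values shown sits.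

Going by these compounds, how far compound 3 lies from the other three compounds stays open, and so does whether the lower number of compound 4 holds for other groups on the same aryl. On these data alone, how an amine or a carboxylic acid on that aryl, or a longer chain in its place on the amide-type nitrogen, would read in this assay also remains open.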